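The source may hold more compounds than are shown below. What is called first, only, known or untested is meant among the compounds shown, and "the series" means these compounds.

In an in vitro assay on BTI-TN-5B1-4 cells for inhibition of Amine oxidase [flavin-containing] B (Homo sapiens) (on this read-out lower numbers stand for stronger inhibition and higher numbers for weaker inhibition), the three measured compounds stand as follows:

compound 1 `Cc1ccc([C@H]2CC(=O)c3ccc(C)cc3O2)cc1` gives 530 nM
compound 2 `Cc1ccc(C2CC(=O)c3ccccc3O2)cc1` gives 2070 nM
compound 3 `Cc1ccc2c(c1)O[C@@H](c1ccccc1)CC2=O` gives 140 nM

Compound 3 differs from compound 1 by hydrogen in place of methyl on an aromatic carbon and in this assay that change made a 3.8-fold lower number from compound 1 to compound 3 (0.58 log units; beyond the scatter). Compound 2 has the highest number of the three; the difference between its core and the core of compound 1 is not broken down here.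

Compound 4 `O=C1CC(c2ccccc2)Oc2ccccc21` has not yet been measured in this assay. It differs from compound 2 by hydrogen in place of methyl on an aromatic carbon. The place is described in the same words as for the change from compound 1 to compound 3, so this is the same change made a second time; among the compounds shown it occurs twice in all. The expected step from compound 2 to compound 4 is estimated at a 3.5-fold lower number from compound 2 to compound 4 (0.54 log units; beyond the scatter), resting on the earlier step of a 3.8-fold lower number from compound 1 to compound 3 (0.58 log units; beyond the scatter) seen in compound 1 and compound 3. Among the measured compounds shown here, because that step is the only example, and the cores of compound 2 and compound 1 differ in a way not broken down here, the range is kept wide. Compound 4 is expected to give about 600 nM in this assay, estimated between 250 nM and 1500 nM.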

Compound 4, half-maximal inhibitory concentration: 2870 nM
Compound 4: the middle estimate sits 4.8-fold (0.68 log units) below what was measured; measured number above the stated range.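

In this assay, hydrogen in place of methyl on the aromatic carbon gives a 1.4-fold higher number from compound 2 to compound 4 (0.14 log units; within the scatter), so on this core the change cannot be told apart from the scatter of repeated measurements. Compound 1 and compound 3 are drawn with a defined stereocentre, while compound 2 and compound 4 are drawn without one, and two pairs cannot show whether this or the other difference between the cores matters, nor how the change would behave on a third core. What they do show is that the change does not carry over as a fixed step between these two cores: the same change on two cores in this assay, a 3.8-fold lower number (0.58 log units; beyond the scatter) from compound 1 to compound 3 and a 1.4-fold higher number (0.14 log units; within the scatter) from compound 2 to compound 4, 5.2-fold (0.72 log units) apart, beyond the scatter of two such steps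

The compounds shown have only methyl or hydrogen at this place, so it remains open how a methoxy group, a chlorine atom or an amine there would read on either core. Among the compounds shown here, it also remains open whether the single stereoisomers of compound 2 and compound 4 would follow the step seen on the core of compound 1.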